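Anilide in Place of Alkynyl Ester on the Shared Core

The compounds below may be only part of what the source reports. "The series", "measured", "known", "first", "only" and "open" are said of these compounds alone.

Measured compounds:
compound 1 `CCN(CC)CCNC(=O)c1ccc(C(CC)(CC)c2ccc(OCC(=O)C(C)(C)C)c(C)c2)n1CC` with 91 nM
compound 2 `CCn1c(C(=O)NCCN(C)C)ccc1C(CC)(CC)c1ccc(OCC(=O)C(C)(C)C)c(C)c1` with 77 nM
compound 3 `C#CCCOC(=O)c1ccc(C(CC)(CC)c2ccc(OCC(=O)C(C)(C)C)c(C)c2)n1CC` with 28800 nM

In an assay on HL-60 cells for agonist activity at vitamin D3 receptor (Homo sapiens), read by microscopy, with a stated time of 96 h (a higher number here means that more compound is needed for the effect, a lower number that less compound is needed), compound 3 stands highest of the three numbers. The two amides lie far below it: a 320-fold higher number from compound 1 to compound 3 (2.50 log units; beyond the scatter) and a 370-fold higher number from compound 2 to compound 3 (2.57 log units; beyond the scatter) both mark large steps beyond the scatter, while a 1.2-fold lower number from compound 1 to compound 2 (0.07 log units; within the scatter) shows that the two amino-alkyl amides are indistinguishable from each other.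

Compound 4 `CCn1c(C(=O)Nc2cccc(C(F)(F)F)c2)ccc1C(CC)(CC)c1ccc(OCC(=O)C(C)(C)C)c(C)c1` differs from compound 3 in one place: (3-(trifluoromethyl)phenyl)amino in place of (but-3-yn-1-yl)oxy on a carbonyl carbon. Both measured steps bear on this change in that each swaps an amide for this ester and the number rises steeply; the present step runs the other way, from ester back to amide. Among the compounds with values here, it does not match them exactly, however, since the entering group is an aromatic amine with no basic chain, and no measured compound carries such a group. A lower number than compound 3 is therefore expected in this assay, with a step of roughly a 24-fold lower number from compound 3 to compound 4 (1.38 log units; beyond the scatter), smaller than a full return to the level of compound 1. The estimate for compound 4 is 1200 nM, with a range from 150 nM to 9000 nM.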

Compound 4, half-maximal effective concentration: > 50000 nM
Compound 4: no number, only a limit; the forecaster's own chance of this, stated with the estimate: 5%; middle value at least 41-fold (1.61 log units) from the limit.
By their numbers in this assay, from the lowest: compounds 2 and 1 (each within the scatter of the next); then compound 3. At a limit, above all of these: compound 4.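

Compound 4 gives no number in this assay, only a limit: (the limit of > 50000 nM in this assay, at which 1 of the 4 values shown sits). Within the data shown here, the earlier compounds set amides with amino-ethyl chains against an ester, and compound 4 now shows that an amide on this carbonyl carbon does not by itself bring the low numbers back: its floor against the ester (an at least 1.7-fold higher number from compound 3 to compound 4 (0.23 log units; that floor lies within the scatter)) lies within the scatter, so no gain over compound 3 can be claimed and the true size of the step stays unknown. The change on the amide-type nitrogen is large whichever chain leaves (an at least 640-fold higher number from compound 2 to compound 4 (2.81 log units; beyond the scatter); an at least 540-fold higher number from compound 1 to compound 4 (2.73 log units; beyond the scatter)), so among the four compounds the low numbers belong to the two amides with amino-ethyl chains, and compound 4 is the amide that goes against any link between the amide alone and low numbers.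

The compounds shown leave open whether the terminal amine or the chain itself matters, a question that a plain butyl or 2-hydroxyethyl group on the amide-type nitrogen would address. They also leave open whether the trifluoromethyl group or the phenyl ring accounts for the loss, which an unsubstituted phenylamino group on the carbonyl carbon would help to separate.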